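The source may report more compounds than this note shows. Statements on the series, on what has been measured and on what is new or still open speak of the compounds shown alone.

Of the compounds shown here, two have been measured in an ADME assay on the whole organism (Rattus norvegicus, strain Sprague-Dawley) for pharmacokinetics, read by LC-MS, with a stated time of 24 h, at a dose of 10 mg/kg by the oral route; a higher number here means more compound in the circulation at the dose given, a lower number less compound in the circulation. Compound 1, `Cn1nccc1-c1cc(C(F)(F)F)ccc1[C@H]1CCc2cc(S(=O)(=O)Nc3ncccn3)ccc21`, gives 10900 nM. Compound 2, `O=S(=O)(Nc1ncccn1)c1ccc2c(c1)OCC[C@@H]2c1ccc(C(F)(F)F)cc1-c1ccc(F)nc1`, gives 6600 nM, and with that number compound 2 sits alongside compound 1, the two values lying within the usual scatter of each other, so neither is set apart from the other.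

Compound 3, `Cn1nccc1-c1cc(C(F)(F)F)ccc1[C@H]1CCOc2cc(S(=O)(=O)Nc3ncccn3)ccc21`, has not yet been measured. It differs from compound 2 in one place: 1-methyl-1H-pyrazol-5-yl in place of 6-fluoropyridin-3-yl on an aromatic carbon. The group that enters is the same one that compound 1 carries on its own core.

For the measured compounds named here, no directly comparable step has been measured for this assay. Because compound 1, which carries this very group, gives 10900 nM, the step from compound 2 to compound 3 is expected to be a 1.4-fold higher number from compound 2 to compound 3 (0.13 log units; within the scatter), that is, no change beyond the scatter. Compound 3 is therefore estimated to give 9000 nM, with a likely range from 4000 nM to 20000 nM.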

Compound 3, maximal plasma concentration: 13000 nM
Estimate against measurement, compound 3: 1.4-fold (0.16 log units) below; measured number inside the range.
By their numbers in this assay, from the lowest: compounds 2, 1 and 3 (each within the scatter of the next).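

In this assay, for the compounds shown here, placing 1-methyl-1H-pyrazol-5-yl in place of 6-fluoropyridin-3-yl on this aromatic carbon, ortho to a large group and meta to a trifluoromethyl group, gives a 2.0-fold higher number from compound 2 to compound 3 (0.29 log units; within the scatter), the first comparison in which only this position differs. At this position, then, a five-membered aromatic ring with 2 hetero atoms and a six-membered aromatic ring with 1 hetero atom are not told apart by this read-out at the dose given. Nothing measured here bears on what lies behind this result.

Going by these compounds, both groups compared so far are aromatic rings, so it remains open whether a quite different group on this carbon, such as an amine or a carboxylic acid, would give a step beyond the scatter. This single step also leaves open whether the same swap would give a similar result on another core.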